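This account rests on a few compounds, and the source may have more. Where it says the series, first, only, none or still open, it means among the compounds named here.

In a toxicity assay on THP-1 cells (Homo sapiens) for inhibition (on this read-out lower numbers stand for higher toxicity in this test and higher numbers for lower toxicity in this test), compound 1 `COc1ccc(-c2noc(NC(=O)c3ccc(F)cc3)c2C)cc1` gives > 100000 nM, which is a limit of the test and not a number. Compound 2 `COc1ccc(-c2cnc(NC(=O)c3ccccn3)n2C)cc1` also reaches only that limit: in this assay compound 2 gives > 100000 nM. So compound 2 stands where both values shown sit, at the limit (the limit of > 100000 nM in this assay, at which 2 of the 2 values shown sit); nothing separates it from compound 1 on these numbers, and no step between measured compounds is available.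

Compound 3 `COc1ccc(-c2cnc(NC(=O)c3ccccc3Br)n2C)cc1` has not yet been measured. It differs from compound 2 in one place 2-bromophenyl in place of pyridin-2-yl on a carbonyl carbon: a 2-bromophenyl group enters where a pyridin-2-yl group leaves, on a carbonyl carbon whose other neighbour is an amide-type nitrogen.

With both known compounds sitting at the limit, the step from compound 2 to compound 3 in this assay is expected to be none beyond the scatter, a number no higher from compound 2 to compound 3 (the limit leaves the size open). Compound 3 is therefore estimated at 100000 nM in this assay, in the range 30000 nM to 300000 nM, most likely again reported only as a limit.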

Compound 3, half-maximal cytotoxic concentration: > 100000 nM
Compound 3 was reported as a limit; the forecaster's own chance of this, stated with the estimate: 80%; the middle value lies on the limit itself.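

In this assay no step can be read between compound 2 and compound 3, since each stands at a limit of the test and not at a number: the limit of > 100000 nM in this assay, at which 3 of the 3 values shown sit.

On these data alone, whether 2-bromophenyl in place of pyridin-2-yl shifts this read-out at all stays open.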